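Swapping 4-methoxybenzyl for 2-chlorobenzyl: an expected step

A few compounds are considered here, and "the series" means these few. Any claim that something is new, unique, unknown or untested is made for them only; others in the source may bear on it.

Measured so far in a functional assay on the whole organism with Rattus norvegicus as the target; on this read-out lower numbers stand for an effect already at smaller amounts and higher numbers for an effect only at larger amounts of compound:
- compound 1 `CCN(CCNC(=O)c1cc(Cl)c(N)cc1OC)Cc1ccccn1`: 30 mg/kg
- compound 2 `CCN(CCNC(=O)c1cc(Cl)c(N)cc1OC)Cc1ccc(OC)cc1`: 0.2 mg/kg

Of the two numbers available, compound 2 holds the lower one, 0.2 mg/kg. Within the data shown here, its only measured neighbour is compound 1, and the gap between them, a 150-fold lower number from compound 1 to compound 2 (2.18 log units; beyond the scatter), is large.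

The next compound is compound 3 `CCN(CCNC(=O)c1cc(Cl)c(N)cc1OC)Cc1ccccc1Cl`, which has not yet been measured. It keeps the shared core and differs from compound 2 in one group: 2-chlorophenyl in place of 4-methoxyphenyl on a saturated chain carbon bound to an amine nitrogen. The same change can be read as 4-methoxybenzyl to 2-chlorobenzyl.

Among the measured compounds shown here, only one measured step bears on this change. That step, a 150-fold lower number from compound 1 to compound 2 (2.18 log units; beyond the scatter), occurs at the same place and shows that the number in this assay can move widely there. However, it involves pyridin-2-yl, and no measured compound carries 2-chlorophenyl, so it gives a scale rather than a direct precedent. A moderate move towards a higher number is expected, well short of that large step, and the estimate is a 5.0-fold higher number from compound 2 to compound 3 (0.70 log units; beyond the scatter). For compound 3 the expected value is 1 mg/kg, with an estimated range from 0.2 mg/kg to 6 mg/kg.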

Compound 3, dose for half-maximal effect: 10 mg/kg
Compound 3: middle estimate off by 10-fold (1.00 log units), on the low side, outside the stated range (above it).
By their numbers in this assay, from the lowest: compound 2; then compound 3; then compound 1.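

In this assay, the large step of a 50-fold higher number from compound 2 to compound 3 (1.70 log units; beyond the scatter) shows that a carbon-only aromatic ring on the saturated chain carbon bound to the amine nitrogen does not by itself bring the low number of compound 2, which the pyridin-2-yl comparison alone could not show. The step of a 3.0-fold lower number from compound 1 to compound 3 (0.48 log units; beyond the scatter) is modest by comparison, so 2-chlorophenyl improves on pyridin-2-yl here but recovers only part of the gap, leaving compound 2 alone at the low end of the three and making the identity of the substituent on the ring, and not only the ring itself, matter at this position. No measured information is available to explain these differences.

The change from 4-methoxyphenyl to 2-chlorophenyl alters both the substituent and its numbered ring position at once, and the compounds shown do not separate these two changes. They also leave open how a plain phenyl, or an ethoxy or hydroxyl group in place of the methoxy, would read in this assay.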